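Sulfonamide nitrogen substituents on the iodoquinoline core

A few compounds are considered here, and "the series" means these few. Any claim that something is new, unique, unknown or untested is made for them only; others in the source may bear on it.

Measured compounds:
compound 1, `NS(=O)(=O)c1ccc(F)c2ncc(I)cc12`, gives 86600 nM in an assay for inhibition of methylcytosine dioxygenase TET2 (Homo sapiens), read by mass spectrometry, with stated times of 30 min and 1 h; on this read-out higher numbers stand for weaker inhibition and lower numbers for stronger inhibition.
compound 2, `O=S(=O)(NC1CCCCC1)c1ccc(F)c2ncc(I)cc12`, gives only a limit of > 200000 nM in this assay.

Compound 2 stands at the top of the numbers shown: its value in this assay is a limit and not a number, so only a floor for its half-maximal inhibitory concentration is known (the limit of > 200000 nM in this assay, at which 1 of the 2 values shown sits). For the measured compounds named here, the one measured step in this set is an at least 2.3-fold higher number from compound 1 to compound 2 (0.36 log units; beyond the scatter), which is beyond the scatter and is itself bounded below by that limit.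

Compound 3, `O=S(=O)(Nc1cccc(O)c1)c1ccc(F)c2ncc(I)cc12`, differs from compound 2 by 3-hydroxyphenyl in place of cyclohexyl on a sulfonamide nitrogen. The sole step that bears on this position runs from the unsubstituted sulfonamide nitrogen to the cyclohexyl analogue and points towards weaker inhibition; no measured step speaks to an aromatic or hydroxyl-bearing substituent at this nitrogen, so the direction from compound 2 to compound 3 cannot be read off any shown pair. The expected step of an at least 1.3-fold lower number from compound 2 to compound 3 (0.12 log units; that floor lies within the scatter) is therefore taken as none beyond the scatter, with the full measured spread from compound 1 to compound 2 as its uncertainty. For compound 3 the estimate in this assay is 150000 nM, within 40000 nM to 400000 nM, with a substantial chance that only a limit is again reported.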

Compound 3, half-maximal inhibitory concentration: > 200000 nM
Compound 3: a limit, no number; the forecaster's own chance of this, stated with the estimate: 50%; at least 1.3-fold (0.12 log units) between middle value and limit.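

In this assay, 3-hydroxyphenyl on the sulfonamide nitrogen gives an at least 2.3-fold higher number from compound 1 to compound 3 (0.36 log units; beyond the scatter), so a second substituent now moves in the same direction as cyclohexyl, relative to the unsubstituted sulfonamide. For the compounds shown here, exchanging the non-aromatic carbon ring for an aromatic one bearing a hydroxyl therefore does not restore a measurable number in this set, and compound 1 remains the only compound with one. The step from compound 2 to compound 3 cannot be read, and no order between these two compounds can be stated, as each stands at a limit and not a number: the limit of > 200000 nM in this assay, at which 2 of the 3 values shown sit.

On these data alone, it remains open whether a smaller group on this nitrogen, such as methyl, or a short chain ending in an amine or a carboxylic acid, would give a number in this assay. The compounds shown also cannot separate any contribution of the hydroxyl from that of the aromatic ring, as plain phenyl does not appear among them.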